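Working notes: from compound 1 to compound 4

The compounds below may be only part of what the source reports. "The series", "measured", "known", "first", "only" and "open" are said of these compounds alone.

Measured so far:
- Compound 1 `Cc1ccc2c(NCc3ccc(NC(=O)C4CCN(Cc5ncc[nH]5)CC4)cc3)nc(N(C)C)nc2c1`. In a functional assay on SV5A8 cells (Homo sapiens) for cytotoxicity (a lower number here means a stronger inhibitor, a higher number a weaker inhibitor), compound 1 gives only a limit, > 20000 nM.
- Compound 2 `Cc1ccc2c(NCc3ccc(NC(=O)C4CCN(Cc5ccccc5)CC4)cc3)nc(N(C)CCN(C)C)nc2c1`. In this assay compound 2 gives only a limit, > 8830 nM.
- Compound 3 `CCNc1nc(NCc2ccc(NC(=O)C3CCN(Cc4ccccc4)CC3)cc2)c2ccc(C)cc2n1`. In this assay compound 3 gives only a limit, > 2140 nM.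

Compound 1 stands at a limit, (the limit of > 20000 nM in this assay, at which 1 of the 3 values shown sits). The two further values shown are limits as well, one at the limit of > 8830 nM in this assay, at which 1 of the 3 values shown sits, and one at the limit of > 2140 nM in this assay, at which 1 of the 3 values shown sits, so no order among the three compounds can be read, and none can be called stronger or weaker than another.

Among the compounds with values here, the one single-site step among them, a step that the two limits leave unreadable from compound 2 to compound 3, is unreadable because both ends are limits.

Compound 4 `Cc1ccc2c(NCc3ccc(NC(=O)C4CCN(Cc5cc(Cl)ccn5)CC4)cc3)nc(N(C)C)nc2c1` differs from compound 1 as follows: 4-chloropyridin-2-yl in place of 1H-imidazol-2-yl on a saturated chain carbon bound to an amine nitrogen in a ring. Within the data shown here, no measured step bears on this change; the shared core and the amide-bearing part are untouched, and the only step available concerns a different site.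

Compound 4 is therefore expected at 20000 nM, with a range from 5000 nM to 80000 nM, most likely reported as a limit again. The expected step of a number no higher from compound 1 to compound 4 (the limit leaves the size open) is none beyond the scatter.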

Compound 4, half-maximal inhibitory concentration: > 5400 nM
Compound 4 gave a limit, no number; the forecaster's own chance of this, stated with the estimate: 80%; the middle value lies beyond the limit too.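

In this assay compound 4 gives > 5400 nM, which is a limit and not a number. Within the data shown here, compound 1 also stands at a limit, so no step from compound 1 to compound 4 can be read. The compounds shown leave open where any of them would reach a measured half-maximal inhibitory concentration in this assay.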